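Swapping a Methylsulfonyl for a Formyl Group

A few compounds are considered here, and "the series" means these few. Any claim that something is new, unique, unknown or untested is made for them only; others in the source may bear on it.

Of the compounds shown here, three sharing one core have been measured in a functional assay on CHO cells for agonist activity at Alpha-2C adrenergic receptor (Homo sapiens); a higher number here means that more compound is needed for the effect, a lower number that less compound is needed. Compound 1 `CC(Oc1ccccc1OC1CC1)C1=NCCN1` gives 47.9 nM, compound 2 `COc1ccccc1OC(C)C1=NCCN1` gives 9770 nM, and compound 3 `CC(Oc1ccccc1S(C)(=O)=O)C1=NCCN1` gives 316 nM. Compound 3 therefore stands second highest of the three numbers, above compound 1 and well below compound 2. Compound 4 `CC(Oc1ccccc1C=O)C1=NCCN1` is not yet measured; it differs from compound 3 by formyl in place of methylsulfonyl on an aromatic carbon. The measured steps show how strongly this single position matters: a 200-fold higher number from compound 1 to compound 2 (2.31 log units; beyond the scatter), a 31-fold lower number from compound 2 to compound 3 (1.49 log units; beyond the scatter), and a 6.6-fold higher number from compound 1 to compound 3 (0.82 log units; beyond the scatter). Methoxy gave the weakest result, while methylsulfonyl and cyclopropyloxy did far better. Formyl brings fewer heavy atoms than methylsulfonyl but keeps one hydrogen-bond acceptor, so it sits somewhere between these cases. A modest to large step toward a higher number in this assay is expected, namely a 3.2-fold higher number from compound 3 to compound 4 (0.50 log units; beyond the scatter). For compound 4 the expected value is 1000 nM, with a likely range from 200 nM to 5000 nM.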

Compound 4, half-maximal effective concentration: 100 nM
Compound 4: the middle estimate sits 10-fold (1.00 log units) above what was measured, outside the stated range (below it).
By their numbers in this assay, from the lowest: compound 1; then compound 4; then compound 3; then compound 2.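

In this assay, formyl in place of methylsulfonyl gives a better result (a 3.2-fold lower number from compound 3 to compound 4 (0.50 log units; beyond the scatter)), so at this aromatic carbon a group with fewer heavy atoms and fewer hydrogen-bond acceptors does not have to raise the number. Formyl in place of methoxy brings a much larger drop (a 98-fold lower number from compound 2 to compound 4 (1.99 log units; beyond the scatter)), while cyclopropyloxy in place of formyl still keeps the lowest number of the four (formyl's step from it: a 2.1-fold higher number from compound 1 to compound 4 (0.32 log units; beyond the scatter)), so the ranking at this position does not simply follow the heavy-atom count of the two groups compared under each step. No measurement shown here explains why these groups rank in this order.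

From the compounds shown here alone, it remains open how an amine, a carboxylic acid or a nitrile at this place would compare with formyl and cyclopropyloxy. Whether a longer chain on the oxygen would lower the number further is also unsettled.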